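The source may report more compounds than this note shows. Statements on the series, on what has been measured and on what is new or still open speak of the compounds shown alone.

For the measured compounds named here, compound 3 `CCSc1nn2cc(-c3cc4ccccc4o3)nc2s1` is one of three close relatives of which only one carries a number in an assay for antagonist activity at proteinase-activated receptor 4 (Homo sapiens), with stated times of 5 min, 50 s and 15 min, in the presence of a further agent that is not named here; a higher number here means a weaker inhibitor, a lower number a stronger inhibitor. Compound 1 `COc1ccc2oc(-c3cn4nc(OC)sc4n3)cc2c1` gives > 30000 nM in this assay, and that value is a limit of the assay rather than a measured number. For compound 2 `c1ccc(Sc2nn3cc(-c4cc5ccccc5o4)nc3s2)cc1` the result in this assay is "not determined" (no result reported). Going by the values given here, for compound 3 itself the result in this assay is likewise "not determined" (no result reported), so compound 3 has no number of its own to stand on; the only value in its neighbourhood is the limit of > 30000 nM in this assay, at which 1 of the 3 values shown sits.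

Compound 4 `CS(=O)(=O)c1nn2cc(-c3cc4ccccc4o3)nc2s1` differs from compound 3 in one place: methylsulfonyl in place of ethylsulfanyl on an aromatic carbon. Among the compounds with values here, no measured step runs between two numbered compounds here, so the size and direction of this change in this assay cannot be drawn from any measured pair, and no step beyond the usual scatter can be asserted in either direction.

Within the data shown here, with the single value in the set being a limit, compound 4 is estimated at 30000 nM in this assay, with an expected range from 3000 nM to 100000 nM, and a real chance that the assay again returns only a limit.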

Compound 4, half-maximal inhibitory concentration: > 30000 nM
Compound 4: only a limit was reported; the forecaster's own chance of this, stated with the estimate: 65%; the middle value sits exactly at the limit.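

In this assay compound 4 gives > 30000 nM, which is a limit of the assay and not a number. Compound 3 has no number there, so no step can be read between compound 3 and compound 4. The compounds shown leave open what methylsulfonyl in place of ethylsulfanyl does to inhibition, and whether any of them has a measurable potency in this assay.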